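Moving a trifluoromethyl group around the benzyl ring

The compounds below may be only part of what the source reports. "The series", "measured", "known", "first", "only" and "open" are said of these compounds alone.

Compound 1 `COC(=O)C1=CN(C(C)C)C(=O)[C@@H]2C(CN3CCN(Cc4ccc(C(F)(F)F)cc4)CC3)=CC[C@H]12`: 59.1%
Compound 2 `COC(=O)C1=CNC(=O)[C@@H]2C(CO)=CC[C@H]12`: 59%

In a functional assay on Cortical neurone cells (Rattus norvegicus, strain Sprague-Dawley), read by MTT assay, with stated times of 24 h and 2 h, tested at 0.1 uM (on this read-out lower numbers stand for a weaker effect and higher numbers for a stronger effect at the one concentration tested), compound 1 gives 59.1%. In this assay compound 2 gives 59%, a number that sits within the scatter of the value of compound 1, so the two cannot be told apart. Compound 3 `COC(=O)C1=CN(C(C)C)C(=O)[C@@H]2C(CN3CCN(Cc4cccc(C(F)(F)F)c4)CC3)=CC[C@H]12` has not yet been measured. It differs from compound 1 in one place: 3-(trifluoromethyl)phenyl in place of 4-(trifluoromethyl)phenyl on a saturated chain carbon bound to an amine nitrogen in a ring. For the measured compounds named here, no step between measured compounds gives a guide here, so the step from compound 1 to compound 3 is expected to be a number 2.1 percentage points lower from compound 1 to compound 3 (within the scatter), none beyond the scatter. Compound 3 is therefore estimated at 57%, between 40% and 72%.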

Compound 3, a percentage reported as activity, at one concentration (the size of the read-out at that concentration, not a potency): 58.7%
Compound 3: the middle estimate sits 1.7 percentage points below what was measured, within the range that was stated.
By their numbers in this assay, from the lowest: compounds 3, 2 and 1 (each within the scatter of the next).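

In this assay, the step from the 4-(trifluoromethyl)phenyl to the 3-(trifluoromethyl)phenyl isomer is a number 0.4 percentage points lower from compound 1 to compound 3 (within the scatter), so the two placements cannot be told apart at the one concentration tested. For the compounds shown here, this is the first direct comparison at this position, and it shows that this change in the benzyl ring leaves the read-out within the scatter. No supporting measurement bears on this result. On these data alone, it remains open whether a plain benzyl group, or a nitrile or methoxy group in place of trifluoromethyl, would give a different read-out. Whether the two isomers also match at other concentrations is open too.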